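Nitro to chloro in a series resting at its limit

The compounds below may be only part of what the source reports. "The series", "measured", "known", "first", "only" and "open" are said of these compounds alone.

Compound 1 `CC1=CC[C@@H]([C@@](C)(O)CCCC(C)(C)NC(=S)NN)CC1`: > 100000 nM
Compound 2 `CC1=CC[C@@H]([C@@](C)(O)CCCC(C)(C)NC(=S)N/N=C\c2cccc([N+](=O)[O-])c2)CC1`: > 100000 nM
Compound 3 `CC1=CC[C@@H]([C@@](C)(O)CCCC(C)(C)NC(=S)N/N=C\c2ccc([N+](=O)[O-])cc2)CC1`: > 100000 nM

All three compounds were tested in a functional assay on OVCAR-3 cells (Homo sapiens) for cytotoxicity, read by sulforhodamine B assay; a higher number here means that more compound is tolerated, a lower number that less compound is tolerated. Compound 3 gives > 100000 nM, which is a limit and not a number. The same holds for compounds 1 and 2, so the whole set is summed up by the limit of > 100000 nM in this assay, at which 3 of the 3 values shown sit. Among the measured compounds shown here, no compound here has a readable value, and compound 3 therefore has no exact place among the others.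

The next compound is compound 4 `CC1=CC[C@@H]([C@@](C)(O)CCCC(C)(C)NC(=S)N/N=C\c2ccc(Cl)cc2)CC1`. It keeps the shared core of compound 3 and changes one group: chloro in place of nitro on an aromatic carbon.

For the measured compounds named here, only one measured step touches this part of the molecule: a step that the two limits leave unreadable from compound 2 to compound 3. Going by the values given here, that step has no readable size, and no measured step shows what replacing nitro does. With no size to carry over, no step beyond the scatter is expected in this assay. This expectation rests on compound 3, whose > 100000 nM is itself a limit. The expected change is an at least 1.1-fold lower number from compound 3 to compound 4 (0.04 log units; that floor lies within the scatter). Compound 4 is estimated at 90000 nM, with an expected range from 35000 nM to 100000 nM, and it may well be reported only as a limit again.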

Compound 4, concentration lethal to 50% of the cells: 40600 nM
The estimate for compound 4 lay 2.2-fold (0.35 log units) above the measured number, and the stated range covers the measured number.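

In this assay, among the compounds shown here, the change from nitro to chloro, on an aromatic carbon para to a large group, is the first change here that moves the reading, giving an at least 2.4-fold lower number from compound 3 to compound 4 (0.39 log units; beyond the scatter) and so showing that this position can affect the result. For the compounds shown here, the comparisons with the other two compounds point the same way, with an at least 2.4-fold lower number from compound 2 to compound 4 (0.39 log units; beyond the scatter) and an at least 2.4-fold lower number from compound 1 to compound 4 (0.39 log units; beyond the scatter) both beyond the scatter, while the earlier compounds showed only that neither nitrophenyl compound came off the limit. Each of these steps starts from a limit and gives only a minimum size, the step between the two nitrophenyl compounds cannot be read at all, and compound 4 alone has an exact number, while the rest of the set stays at a limit: the limit of > 100000 nM in this assay, at which 3 of the 4 values shown sit.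

On these data alone, how large the drop from nitro to chloro truly is stays unknown, since the real values of the compounds at the limit lie out of reach of these data. As far as these compounds go, it also remains open whether chloro is special at this position or whether other replacements for nitro, such as fluoro, methoxy, an amine or a carboxylic acid, would lower the number as well.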